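Notes on the nitro to fluoro step

A few compounds are considered here, and "the series" means these few. Any claim that something is new, unique, unknown or untested is made for them only; others in the source may bear on it.

Measured so far in a functional assay on HeLa cells (Homo sapiens) for antiproliferative activity, read by MTT assay, with a stated time of 48 h (on this read-out lower numbers stand for stronger inhibition of growth and higher numbers for weaker inhibition of growth), for this series:
- compound 1 `COc1ccc(/C=C2\Cc3c(cc(OC)c(OC)c3OC)C2=O)cc1[N+](=O)[O-]` gives 790 nM as its value
- compound 2 `COc1cc(/C=C2\Cc3c(cc(OC)c(OC)c3OC)C2=O)cc(OC)c1OC` gives 2370 nM as its value
- compound 3 `COc1cc2c(c(OC)c1OC)C/C(=C\c1cc(OC)c(OC)c(OC)c1OC)C2=O` gives > 10000 nM as a limit of the assay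

Compound 1 holds the lowest number, lower than compound 2 beyond the scatter, while compound 3 reports only a limit. Compound 4 `COc1ccc(/C=C2\Cc3c(cc(OC)c(OC)c3OC)C2=O)cc1F` carries the change fluoro in place of nitro on an aromatic carbon and awaits measurement. Among the compounds with values here, no measured step exchanges nitro. Within the data shown here, the only step of an at least 4.2-fold higher number from compound 2 to compound 3 (0.62 log units; beyond the scatter) is methoxy in place of hydrogen on an aromatic carbon and bears on this change only loosely. Compound 2 at 2370 nM also lacks nitro and sits higher than compound 1, so a modest rise toward weaker inhibition is expected. The step expected in this assay is a 2.3-fold higher number from compound 1 to compound 4 (0.36 log units; beyond the scatter) as estimated here. For compound 4 the estimate is 1800 nM with an expected range of 500 nM to 6000 nM in this assay.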

Compound 4, concentration for 50% growth inhibition: 258 nM
Compound 4: middle estimate off by 7.0-fold (0.84 log units), on the high side, outside the stated range (below it).
By their numbers in this assay, from the lowest: compound 4; then compound 1; then compound 2. At a limit, above all of these: compound 3.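

At this position, ortho to a methoxy group and meta to a large group, fluoro in place of nitro gives a 3.1-fold lower number from compound 1 to compound 4 (0.49 log units; beyond the scatter) in this assay for this pair. Nitro is therefore not required on this carbon for inhibition of growth, and fluoro, with fewer heavy atoms and no hydrogen-bond acceptors, gives the lower number. No measurement shown here bears on the reason for this step:.

Open, as far as these compounds go, is whether chloro or an amine on this carbon would give a lower or higher number than fluoro. Also open, from the compounds shown here alone, is whether the step reflects the arrival of fluoro or the departure of nitro.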